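The compounds below may be only part of what the source reports. "The series", "measured", "known", "first", "only" and "open" are said of these compounds alone.

Measured compounds:
compound 1 `O=C(Cn1cnc2scc(-c3ccc(Cl)cc3)c2c1=O)N/N=C/c1ccc(Cl)c([N+](=O)[O-])c1` with 11000 nM in a functional assay on HeLa cells (Homo sapiens) for inhibition, read by MTT assay, with a stated time of 48 h; a higher number here means a weaker inhibitor, a lower number a stronger inhibitor
compound 2 `O=C(Cn1cnc2scc(-c3ccccc3)c2c1=O)N/N=C/c1ccc(Cl)c([N+](=O)[O-])c1` with 11000 nM in this assay

Compound 2 stands level with compound 1 at the digits recorded. Within the data shown here, the single measured step, hydrogen in place of chloro on an aromatic carbon, gave no change at the digits printed from compound 1 to compound 2 (within the scatter); within the scatter the two compounds cannot be told apart in this assay.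

Compound 3 `O=C(Cn1cnc2scc(-c3ccc4ccccc4c3)c2c1=O)N/N=C/c1ccc(Cl)c([N+](=O)[O-])c1` is not yet measured. It differs from compound 2 in one place: naphthalen-2-yl in place of phenyl on an aromatic carbon. Among the measured compounds shown here, no measured step changes the group at this position to a second ring, so the only step that bears on it, no change at the digits printed from compound 1 to compound 2 (within the scatter), shows merely that a change at this aromatic carbon left the reading where it was. On that basis no step beyond the scatter is expected from compound 2 to compound 3 in this assay, and the step is estimated as a 1.2-fold lower number from compound 2 to compound 3 (0.09 log units; within the scatter).

For compound 3 the expected value in this assay is 9000 nM, with a range from 3000 nM to 30000 nM.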

Compound 3, half-maximal inhibitory concentration: 24000 nM
Estimate against measurement, compound 3: 2.7-fold (0.43 log units) below; measured number inside the range.
By their numbers in this assay, from the lowest: compounds 1 and 2 (each within the scatter of the next); then compound 3.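

In this assay, this position, on an aromatic carbon two ring bonds from the ring sulfur, does not accept every change without effect: naphthalen-2-yl in place of phenyl gives a 2.2-fold higher number from compound 2 to compound 3 (0.34 log units; beyond the scatter), and naphthalen-2-yl in place of 4-chlorophenyl gives a 2.2-fold higher number from compound 1 to compound 3 (0.34 log units; beyond the scatter). Among these compounds, the earlier pair showed only that exchanging chloro for hydrogen on the phenyl ring left the reading unchanged, whereas adding a second six-membered aromatic ring is the first change here to pass beyond the scatter, modestly and towards a weaker inhibitor. No measurement to hand explains this step.

From the compounds shown here alone, with a single two-ring group at this position, the series cannot separate an effect of the second ring from one of naphthalen-2-yl alone, and it remains open whether a smaller group such as methyl, a saturated ring such as cyclohexyl or a nitrogen-containing ring such as pyridyl would move the number either way. Going by these compounds, the chloro and nitro groups on the other aromatic ring and the hydrazone linker are the same in all three compounds, so their contribution also remains open.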